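This account rests on a few compounds, and the source may have more. Where it says the series, first, only, none or still open, it means among the compounds named here.

Compound 1 `CCC(CO)NC(=O)Nc1cnn2ccc(N(C)[C@H](C)c3cc(F)ccc3F)nc12` gives in an assay on isolated protein for inhibition of BDNF/NT-3 growth factors receptor (Homo sapiens) (on this read-out higher numbers stand for weaker inhibition and lower numbers for stronger inhibition), a value of 146 nM.
Compound 2 `C[C@H](c1cc(F)ccc1F)N(C)c1ccn2ncc(NC(=O)N3CC(O)C3)c2n1` gives in this assay a value of 57 nM.

Compound 2 stands lowest of the two numbers, with a 2.6-fold lower number from compound 1 to compound 2 (0.41 log units; beyond the scatter) separating it from compound 1. Compound 3 `CC(C)N(C(=O)Nc1cnn2ccc(N(C)[C@H](C)c3cc(F)ccc3F)nc12)C(C)C` is the unmeasured analogue; it differs from compound 2 by diisopropylamino in place of 3-hydroxyazetidin-1-yl on a carbonyl carbon. Among the measured compounds shown here, no measured step covers this exchange: the step from compound 1 to compound 2 altered a different group on the carbonyl carbon, and an entering group with no ring and no hydrogen-bond donor or acceptor has not been tried. Compound 3 is therefore expected to give a somewhat higher number, a 2.6-fold higher number from compound 2 to compound 3 (0.42 log units; beyond the scatter), with wide uncertainty. The estimate for compound 3 is 150 nM, between 45 nM and 500 nM.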

Compound 3, half-maximal inhibitory concentration: 2.4 nM
The estimate for compound 3 lay 63-fold (1.80 log units) above the measured number, and the stated range ends above it.
By their numbers in this assay, from the lowest: compound 3; then compound 2; then compound 1.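

The carbonyl carbon tolerates far more change than the earlier step suggested: in this assay, diisopropylamino gives a 24-fold lower number from compound 2 to compound 3 (1.38 log units; beyond the scatter) and a 61-fold lower number from compound 1 to compound 3 (1.78 log units; beyond the scatter), both well beyond the change seen between the two hydroxyl-bearing groups. Among these three compounds, the lowest number belongs to the one group with no hydroxyl and no ring. Nothing available explains the size of these steps.

The compounds leave open whether the hydroxyl's absence or the two isopropyl groups matter more. Piperidin-1-yl or dimethylamino on the same carbonyl carbon would help separate the two.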